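Swapping a neopentyl arm for a fluorobenzyl arm

The source may hold more compounds than are shown below. What is called first, only, known or untested is meant among the compounds shown, and "the series" means these compounds.

Three close relatives of one amide core have been measured in an assay on cells for antagonist activity at transient receptor potential cation channel subfamily V member 1 (Homo sapiens), read by FLIPR and calcium flux, with a stated time of 6 min; on this read-out higher numbers stand for weaker inhibition and lower numbers for stronger inhibition. Compound 1 `CCCCN(C)c1cc(C(C)(C)C)ccc1CNC(=O)C(C)c1ccc(NS(C)(=O)=O)c(F)c1` gives 1 nM there. Where compound 1 carries a butyl(methyl)amino group on the aromatic ring, compound 2 `CCCOc1cc(C(C)(C)C)ccc1CNC(=O)C(C)c1ccc(NS(C)(=O)=O)c(F)c1` carries a propoxy group and gives 4.4 nM; that is a 4.4-fold higher number from compound 1 to compound 2 (0.64 log units; beyond the scatter). Compound 3 `CC(C(=O)NCc1ccc(C(C)(C)C)cc1OCC(C)(C)C)c1ccc(NS(C)(=O)=O)c(F)c1` gives 3.8 nM in this assay and so stands second highest of the three numbers: there is a 1.2-fold lower number from compound 2 to compound 3 (0.06 log units; within the scatter), while there is a 3.8-fold higher number from compound 1 to compound 3 (0.58 log units; beyond the scatter).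

Compound 4 `CC(C(=O)NCc1ccc(C(C)(C)C)cc1OCc1ccc(F)cc1)c1ccc(NS(C)(=O)=O)c(F)c1` has not yet been measured. It differs from compound 3 in one place: 4-fluorophenyl in place of tert-butyl on a saturated chain carbon bound to an oxygen on an aromatic ring. Within the data shown here, the only measured step at that spot is the one where the group on the oxygen-bound carbon grows from ethyl to tert-butyl, and that pair of numbers lies within the usual scatter of each other, as a 1.2-fold lower number from compound 2 to compound 3 (0.06 log units; within the scatter) shows. Among the measured compounds shown here, no measured pair exchanges a saturated group for an aromatic ring at that spot, so the incoming ring is an untested element here. On that basis the step of a 1.1-fold higher number from compound 3 to compound 4 (0.02 log units; within the scatter) is expected to be small, with its direction uncertain. Compound 4 is therefore estimated at 4 nM in this assay, with a likely range from 1.5 nM to 12 nM.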

Compound 4, inhibition constant: 3.8 nM
The estimate for compound 4 lay 1.1-fold (0.02 log units) above the measured number, and the stated range covers the measured number.
By their numbers in this assay, from the lowest: compound 1; then compounds 3, 4 and 2 (each within the scatter of the next).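

In this assay, among these compounds, the ether arm now carries an aromatic ring for the first time, and 4-fluorophenyl in place of tert-butyl on the saturated chain carbon bound to the oxygen gives no change at the digits printed from compound 3 to compound 4 (within the scatter) and so no readable effect on the number, which shows that this carbon can hold a fluorine-bearing aromatic ring as well as a saturated group. The comparison with the ethyl group of the propoxy compound reads the same way, with a 1.2-fold lower number from compound 2 to compound 4 (0.06 log units; within the scatter), yet the gap to the amine remains, since a 3.8-fold higher number from compound 1 to compound 4 (0.58 log units; beyond the scatter), and so this third ether, like the other two, stays apart from the butyl(methyl)amino compound. No supporting information is available to explain why such different groups give numbers within the scatter of one another.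

Going by these compounds, it remains open whether this tolerance extends to an arm ending in an amine, a carboxylic acid or a much longer chain. On these data alone, it is also open whether a 4-fluorobenzyl group on the nitrogen of a methylamino linkage would match the butyl(methyl)amino compound.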